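Oxime for Ketone on a Triazole Thioether Series

The source may report more compounds than this note shows. Statements on the series, on what has been measured and on what is new or still open speak of the compounds shown alone.

Within the data shown here, compound 3 `CCn1c(SCC(=O)c2ccccc2)nnc1-c1cc(OC)c(OC)c(OC)c1` is one of three compounds measured in a functional assay on the whole organism (strain albino) for inhibition, with Rattus norvegicus as the target, read by paw edema, with a stated time of 4 h, at a dose of 0.28 mmol/kg by the oral route (on this read-out higher numbers stand for more inhibition at the one dose given (going by the name of the read-out) and lower numbers for less inhibition), where it gives 72%, the second highest of the three numbers. Compound 1 `O/N=C(/CSc1nnc(-c2ccccc2)n1-c1ccccc1)c1ccccc1` gives 79% in this assay, and compound 2 `CCn1c(SCC(=O)c2ccccc2)nnc1-c1ccccc1` gives 63%; both neighbours of compound 3 lie within the usual scatter of it. Compound 4 `CCn1c(SC/C(=N/O)c2ccccc2)nnc1-c1cc(OC)c(OC)c(OC)c1` has not yet been measured. It differs from compound 3 in one place: a group of 9 heavy atoms (7 carbon, 1 nitrogen, 1 oxygen; one six-membered aromatic ring of carbon only) in place of a group of 8 heavy atoms (7 carbon, 1 oxygen; one six-membered aromatic ring of carbon only), on a saturated chain carbon bound to a sulfur. Among the measured compounds shown here, no measured pair isolates this exchange, but compound 1, which carries the same nitrogen-oxygen group, gives 79%. Compound 4 is therefore expected to show a small upward step, a number 6 percentage points higher from compound 3 to compound 4 (within the scatter), not clearly beyond the scatter. Compound 4 is estimated at 78%, with a likely range from 65% to 90%.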

Compound 4, a percentage reported as inhibition, in the whole organism at one dose (the size of the read-out at that dose, not a potency): 79%
The estimate for compound 4 lay 1 percentage points below the measured number; the range from low to high includes it.
By their numbers in this assay, from the lowest: compounds 2, 3, 1 and 4 (each within the scatter of the next, the first and the last beyond it).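

Among these compounds, on a saturated chain carbon bound to a sulfur, the exchange of benzoyl for the group with no common name gives in this assay a number 7 percentage points higher from compound 3 to compound 4 (within the scatter) and is the first measured pair to isolate this change. At this one dose, the two groups are therefore not separated, and the place accepts the added hydrogen-bond donor without a drop beyond the scatter. Nothing available gives a reason for this result. Going by these compounds, whether an amine or a carboxylic acid at this place would keep the inhibition remains open. So does whether the same exchange would give a similar step on the core of compound 2.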